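The compounds below may be only part of what the source reports. "The series", "measured", "known", "first", "only" and "open" are said of these compounds alone.

In a functional assay (aorta) with Rattus norvegicus as the target (a higher number here means that more compound is needed for the effect, a lower number that less compound is needed), compound 1, with the structure `CNC(=O)C1=CC(C)(C)Oc2ccc([N+](=O)[O-])cc21`, gives 10.7 nM. Compound 2, `CNC(=O)C1=CC(C)(CF)Oc2ccc([N+](=O)[O-])cc21`, differs from it by fluoro in place of hydrogen on a saturated chain carbon bound to a saturated ring carbon, and in this assay compound 2 gives 8.91 nM, a step of a 1.2-fold lower number from compound 1 to compound 2 (0.08 log units; within the scatter). Compound 3, `CC1(CF)C=C(C(=O)NCCC#N)c2cc([N+](=O)[O-])ccc2O1`, carries a larger amide substituent; in this assay compound 3 gives 3.98 nM, the step from compound 2 being a 2.2-fold lower number from compound 2 to compound 3 (0.35 log units; beyond the scatter). The difference between the cores of compound 3 and compound 1 is not broken down here. Compound 4, `N#CCCNC(=O)C1=CC(CF)(CF)Oc2ccc([N+](=O)[O-])cc21`, is not yet measured; it differs from compound 3 by fluoro in place of hydrogen on a saturated chain carbon bound to a saturated ring carbon, the same change seen from compound 1 to compound 2. A step of about a 1.1-fold lower number from compound 3 to compound 4 (0.06 log units; within the scatter) is expected in this assay because the earlier step was a 1.2-fold lower number from compound 1 to compound 2 (0.08 log units; within the scatter). For compound 4 an estimated 3.5 nM, between 1.8 nM and 7 nM, is expected.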

Compound 4, half-maximal effective concentration: 2.24 nM
Beside the measured number, compound 4's estimate is 1.6-fold (0.19 log units) above it; the range from low to high includes it.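

Placing fluoro in place of hydrogen on a saturated chain carbon bound to a saturated ring carbon, this time on the core of compound 3, gives a 1.8-fold lower number from compound 3 to compound 4 (0.25 log units; within the scatter) in this assay. Set beside the same change on the core of compound 1, the two steps agree: the same change on two cores in this assay, a 1.2-fold lower number (0.08 log units; within the scatter) from compound 1 to compound 2 and a 1.8-fold lower number (0.25 log units; within the scatter) from compound 3 to compound 4, 1.5-fold (0.17 log units) apart, within the scatter of two such steps So on these two cores the change carries over with no difference that can be told apart, but each step is itself within the scatter, which shows no clear effect of the change and says nothing about other cores.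

The compounds shown leave open how an amine, a hydroxyl group or a longer chain would fare in place of fluoro. They also leave open whether the step stays the same with a carboxylic acid in place of the amide.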